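Swapping nitro for chloro on a spirocyclic nitric oxide inhibitor

The source may report more compounds than this note shows. Statements on the series, on what has been measured and on what is new or still open speak of the compounds shown alone.

Three compounds that share a spirocyclic core carrying a phenyl group on the amide nitrogen have been tested in a functional assay on BV-2 cells (Mus musculus), read by Griess assay, with a stated time of 24 h; a lower number here means a stronger inhibitor, a higher number a weaker inhibitor. Compound 1 `O=C1C=CC2(C=C1)OCC(Cc1ccc(Cl)cc1)C(=O)N2c1ccccc1` gives 540 nM in this assay. Compound 2 `O=C1C=CC2(C=C1)OCC(Cc1ccc([N+](=O)[O-])cc1)C(=O)N2c1ccccc1` gives 430 nM. Compound 3 `O=C1C=CC2(C=C1)OCC(Cc1cc(C(F)(F)F)ccc1[N+](=O)[O-])C(=O)N2c1ccccc1` gives 970 nM, the highest of the three numbers.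

Compounds 1 and 2 differ in one place: chloro in place of nitro on an aromatic carbon. The step of a 1.3-fold higher number from compound 2 to compound 1 (0.10 log units; within the scatter) is small and lies within the usual scatter, so the two numbers cannot be told apart with confidence.

Compound 4 `O=C1C=CC2(C=C1)OCC(Cc1cc(C(F)(F)F)ccc1Cl)C(=O)N2c1ccccc1` has not yet been measured. It stands to compound 3 as compound 1 stands to compound 2: chloro in place of nitro on an aromatic carbon. The two cores of compound 2 and compound 3 differ in more than one place, so that difference is not broken down here. The surroundings of the change also differ: in the measured pair the chloro sits para to a large group, while in compound 4 it sits ortho to a large group and para to a trifluoromethyl group. It is therefore the same kind of change, not the same change.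

On the strength of the measured step, compound 4 is expected to behave much like compound 3, with an estimated step of a 1.3-fold higher number from compound 3 to compound 4 (0.11 log units; within the scatter). The estimated value for compound 4 in this assay is 1250 nM, plausibly between 600 nM and 2600 nM.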

Compound 4, half-maximal inhibitory concentration: 770 nM
For compound 4 the middle estimate is 1.6-fold (0.21 log units) above the measured one, and the stated range covers the measured number.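

In this assay, chloro in place of nitro on the second core gives a 1.3-fold lower number from compound 3 to compound 4 (0.10 log units; within the scatter). Set beside the earlier step, the same swap reads alike on both cores as far as these numbers can tell: the same change on two cores in this assay, a 1.3-fold higher number (0.10 log units; within the scatter) from compound 2 to compound 1 and a 1.3-fold lower number (0.10 log units; within the scatter) from compound 3 to compound 4, 1.6-fold (0.20 log units) apart, within the scatter of two such steps

This shows that, in both pairs, the nitro compound and its chloro partner cannot be told apart in this assay, even though the swapped group sits in different surroundings on the two cores, ortho to a large group and para to a trifluoromethyl group in compound 4. It does not show that the two groups are truly equal, since a small real difference could hide within the scatter, and two pairs are too few to predict the result of the swap on any further core.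

The compounds shown leave open whether the same aromatic carbon could carry a different group, such as an amine, a carboxylic acid or a nitrile, or only hydrogen, and still give numbers like these. They also leave open whether the swap would read the same way if the phenyl group on the amide nitrogen gave way to something else, such as a longer chain.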